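Replacing Azido with Propyl on the Amide Chain

The compounds below may be only part of what the source reports. "The series", "measured", "known", "first", "only" and "open" are said of these compounds alone.

Compound 3 `COc1ccc(CN(C(=O)CN=[N+]=[N-])c2cc(OC)c(OC)c(OC)c2)cc1O` carries an azido group on the saturated chain carbon bound to the carbonyl carbon. In a functional assay on HCT-116 cells (Homo sapiens) for inhibition, read by MTT assay, with a stated time of 48 h (on this read-out lower numbers stand for stronger inhibition and higher numbers for weaker inhibition), compound 3 gives 410 nM, the highest of the three numbers recorded. Compound 2 `COc1ccc(CN(C(C)=O)c2cc(OC)c(OC)c(OC)c2)cc1O` gives 270 nM, and since a 1.5-fold higher number from compound 2 to compound 3 (0.18 log units; within the scatter), the two cannot be told apart; compound 1 `CCC(=O)N(Cc1ccc(OC)c(O)c1)c1cc(OC)c(OC)c(OC)c1` gives 61 nM, and a 6.7-fold higher number from compound 1 to compound 3 (0.83 log units; beyond the scatter). Compound 4 `CCCCC(=O)N(Cc1ccc(OC)c(O)c1)c1cc(OC)c(OC)c(OC)c1` differs from compound 3 in one place: propyl in place of azido on a saturated chain carbon bound to a carbonyl carbon. Within the data shown here, two measured steps bear on this position. The step of a 4.4-fold higher number from compound 1 to compound 2 (0.65 log units; beyond the scatter) and the step of a 6.7-fold higher number from compound 1 to compound 3 (0.83 log units; beyond the scatter) both show that compound 1, with methyl at this carbon, gives the lowest number of the three, while hydrogen and azido give higher numbers. Propyl is a carbon chain like methyl rather than a nitrogen group, so compound 4 is expected to move toward compound 1, though no measured compound shows how far a chain of this length is tolerated. For compound 4 the expected step is a 3.4-fold lower number from compound 3 to compound 4 (0.53 log units; beyond the scatter). Compound 4 is therefore estimated at 120 nM, with a range from 40 nM to 400 nM.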

Compound 4, half-maximal inhibitory concentration: 170 nM
Beside the measured number, compound 4's estimate is 1.4-fold (0.15 log units) below it; the measured number falls inside the stated range.
By their numbers in this assay, from the lowest: compound 1; then compounds 4, 2 and 3 (each within the scatter of the next, the first and the last beyond it).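

Propyl at the saturated chain carbon bound to a carbonyl carbon reads better than azido in this assay, with a 2.4-fold lower number from compound 3 to compound 4 (0.38 log units; beyond the scatter) as the measured step, so a chain of this length is tolerated here. The gain seen with methyl does not carry on as the chain grows: a 2.8-fold higher number from compound 1 to compound 4 (0.45 log units; beyond the scatter) leaves methyl with the lowest number of the groups shown at this carbon, and a 1.6-fold lower number from compound 2 to compound 4 (0.20 log units; within the scatter) puts propyl level with hydrogen. No evidence is at hand on what lies behind these differences.

The compounds shown leave open how ethyl, a branched chain such as isopropyl or a chain longer than propyl would read at this carbon. They also leave open whether an amine or a carboxylic acid there would fall nearer to methyl or to azido.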